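The source may report more compounds than this note shows. Statements on the series, on what has been measured and on what is new or still open speak of the compounds shown alone.

Compound 1 `CCO[C@H]1CC[C@H]2CCN(C)[C@H]2C1` gives > 300000 nM in an assay on HEK293 cells for antagonist activity at Neuronal acetylcholine receptor; alpha3/beta4 (Rattus norvegicus), read by FLIPR, using a membrane potential dye (a lower number here means a stronger inhibitor, a higher number a weaker inhibitor), which is a limit of the assay.
Compound 2 `CO[C@H]1CC=C2CCN(C)[C@H]2C1` gives > 300000 nM in this assay, again a limit.
Compound 3 `CCO[C@H]1CC=C2CCN(C)[C@H]2C1` gives > 300000 nM in this assay, also a limit.

Compound 3 therefore stands at the limit and no number is known for it; the same holds for its two measured relatives, as the limit of > 300000 nM in this assay, at which 3 of the 3 values shown sit, records. Within the data shown here, the only one-place step among the measured compounds, a step that the two limits leave unreadable from compound 2 to compound 3, cannot be read because the limit of > 300000 nM in this assay, at which 3 of the 3 values shown sit, puts both of its ends at the limit. Compound 4 `CN1CCC2=CC[C@H](OCc3ccccc3)C[C@@H]21` differs from compound 3 by phenyl in place of methyl on a saturated chain carbon bound to an oxygen on a saturated carbon. Among the measured compounds shown here, no measured step bears on this change, so its size and direction in this assay cannot be taken from the data, and any number for compound 4 rests on the shared core alone. Compound 4 is expected to sit near the limit as well, with an estimated value of 150000 nM and a range from 20000 nM to 300000 nM. This estimate means a step of an at least 2.0-fold lower number from compound 3 to compound 4 (0.30 log units; that floor lies within the scatter), which is offered as an expectation only, since the measured compounds give no readable step.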

Compound 4, half-maximal inhibitory concentration: > 300000 nM
Compound 4: no number, only a limit; the forecaster's own chance of this, stated with the estimate: 65%; middle value at least 2.0-fold (0.30 log units) from the limit.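

Among these compounds, compound 4 also stands at a limit in this assay, so no step to it from compound 2 or compound 3 can be read: the limit of > 300000 nM in this assay, at which 4 of the 4 values shown sit. The compounds shown leave open how far each lies from that limit and whether phenyl in place of methyl changes inhibition at all.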